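A difluorophenyl replaces hexyl on the shared core

This account rests on a few compounds, and the source may have more. Where it says the series, first, only, none or still open, it means among the compounds named here.

Of the compounds shown here, three built on one shared core have been measured in a functional assay on A549 cells (Homo sapiens) for inhibition, read by MTT assay, with a stated time of 72 h; a lower number here means a stronger inhibitor, a higher number a weaker inhibitor. Compound 1 `O=c1cc(Cn2cc(CCCCl)nn2)c2ccc(O)cc2o1` gives 30100 nM. Compound 2 `CC(O)c1cn(Cc2cc(=O)oc3cc(O)ccc23)nn1` reaches only a limit of the assay, > 100000 nM, which is not a number (the limit of > 100000 nM in this assay, at which 1 of the 3 values shown sits). Compound 3 `CCCCCCc1cn(Cc2cc(=O)oc3cc(O)ccc23)nn1` gives 66200 nM, the highest of the two numbers shown, and its nearest neighbour among them is compound 1 .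

Compound 4 `O=c1cc(Cn2cc(-c3cc(F)cc(F)c3)nn2)c2ccc(O)cc2o1` has not yet been measured. It differs from compound 3 in one place: 3,5-difluorophenyl in place of hexyl on an aromatic carbon. Two measured steps change the group on that same aromatic carbon: an at least 3.3-fold higher number from compound 1 to compound 2 (0.52 log units; beyond the scatter), which lies beyond the scatter, and an at least 1.5-fold lower number from compound 2 to compound 3 (0.17 log units; that floor lies within the scatter), whose floor lies within it. The third step, a 2.2-fold higher number from compound 1 to compound 3 (0.34 log units; beyond the scatter), alters the chain further out. All three exchange one open chain for another; none of them places an aromatic ring on that carbon, so they bear on the step to compound 4 only loosely, and the changes they show are of modest size. The expectation is therefore a step of at most modest size, in either direction, for a 1.7-fold lower number from compound 3 to compound 4 (0.22 log units; within the scatter). For compound 4 the estimate in this assay is 40000 nM, with an expected range from 12000 nM to 120000 nM.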

Compound 4, half-maximal inhibitory concentration: 21100 nM
The estimate for compound 4 lay 1.9-fold (0.28 log units) above the measured number; low and high end bracket the measured number.
By their numbers in this assay, from the lowest: compounds 4 and 1 (each within the scatter of the next); then compound 3. At a limit, above all of these: compound 2.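

In this assay, among the compounds shown here, this aromatic carbon of the five-membered ring now carries an aromatic ring for the first time, and the exchange for the open hexyl chain gives a 3.1-fold lower number from compound 3 to compound 4 (0.50 log units; beyond the scatter), a step of modest size that the chain-for-chain exchanges could only loosely foretell. The step that rests on a limit of the assay, which is not a number, can be read only as a floor, an at least 4.7-fold lower number from compound 2 to compound 4 (0.67 log units; beyond the scatter): the limit of > 100000 nM in this assay, at which 1 of the 4 values shown sits. The ring does not stand apart from every chain, however, since the exchange for 3-chloropropyl gives a 1.4-fold lower number from compound 1 to compound 4 (0.15 log units; within the scatter), so 3,5-difluorophenyl and 3-chloropropyl cannot be told apart here, and compound 1 goes against any reading that an aromatic ring on this carbon outdoes an open chain.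

The compounds shown leave open whether the step from the hexyl chain belongs to the ring itself or to its two fluorines, a question that an unsubstituted phenyl or a single fluorine on the ring would address. They also leave open how an amine or a carboxylic acid on the ring would fare at this position.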